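Moving fluorines on the benzoyl group of compound 2

The source may report more compounds than this note shows. Statements on the series, on what has been measured and on what is new or still open speak of the compounds shown alone.

Measured so far:
compound 1 `CN(C(=O)NC(=O)c1ccc(F)c(F)c1)c1nc(C(F)(F)F)c(C(=O)N/N=C/c2ccc(C(F)(F)F)cc2)s1` gives 5.1 ug/mL
compound 2 `CN(C(=O)NC(=O)c1ccc(F)c(F)c1)c1nc(C(F)(F)F)c(C(=O)N/N=C/c2ccccc2C(F)(F)F)s1` gives 9.24 ug/mL
compound 3 `CN(C(=O)NC(=O)c1ccc(F)c(F)c1)c1nc(C(F)(F)F)c(C(=O)N/N=C/c2ccc([N+](=O)[O-])cc2)s1` gives 5.08 ug/mL

In a functional assay on HeLa cells (Homo sapiens) for inhibition, read by MTT assay, with a stated time of 72 h (on this read-out higher numbers stand for weaker inhibition and lower numbers for stronger inhibition), compound 2 carries the largest of the three numbers, yet a 1.8-fold higher number from compound 1 to compound 2 (0.26 log units; within the scatter) and a 1.8-fold lower number from compound 2 to compound 3 (0.26 log units; within the scatter) both fall within the scatter, so the three compounds are not separated. Compound 4 `CN(C(=O)NC(=O)c1c(F)cccc1F)c1nc(C(F)(F)F)c(C(=O)N/N=C/c2ccccc2C(F)(F)F)s1` differs from compound 2 by 2,6-difluorophenyl in place of 3,4-difluorophenyl on a carbonyl carbon. For the measured compounds named here, no measured step touches this part of the molecule: a 1.8-fold higher number from compound 1 to compound 2 (0.26 log units; within the scatter), a 1.0-fold lower number from compound 1 to compound 3 (0.00 log units; within the scatter) and a 1.8-fold lower number from compound 2 to compound 3 (0.26 log units; within the scatter) all change the aryl on the carbon with a double bond to nitrogen and all stay within the scatter. Going by the values given here, with no direct precedent, no step beyond the scatter is expected, a 1.0-fold lower number from compound 2 to compound 4 (0.01 log units; within the scatter). Compound 4 is therefore estimated at 9 ug/mL, with a range from 4 ug/mL to 20 ug/mL.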

Compound 4, half-maximal inhibitory concentration: 19.6 ug/mL
Estimate against measurement, compound 4: 2.2-fold (0.34 log units) below; the measured number falls inside the stated range.
By their numbers in this assay, from the lowest: compounds 3, 1 and 2 (each within the scatter of the next); then compound 4.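

In this assay, for the compounds shown here, 2,6-difluorophenyl in place of 3,4-difluorophenyl on a carbonyl carbon gives a 2.1-fold higher number from compound 2 to compound 4 (0.33 log units; beyond the scatter) and is the only step so far beyond the scatter, though a modest one. Going by these compounds alone, the earlier steps all changed the aryl on the carbon with a double bond to nitrogen, so this is the first sign that the benzoyl ring matters, even with the same atoms joined differently. No evidence at hand bears on this result.

Going by these compounds, whether the same change carries over to the aryl groups of compound 1 and compound 3 remains open. So does what a chlorine or a methoxy group would do on this ring.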